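Cytotoxicity of three measured compounds and one unmeasured

This account rests on a few compounds, and the source may have more. Where it says the series, first, only, none or still open, it means among the compounds named here.

Compound 1 `CC1(Cc2ccccc2)CC(S(=O)(=O)c2ccc(Nc3ccccc3/C(N)=N/O)cc2)=C(c2ccc(/C(N)=N/O)cc2)O1` and compound 2 `CC1(Cc2ccccc2)CC(S(=O)(=O)c2ccc(/C(N)=N/O)cc2)=C(c2ccc(Nc3ccccc3/C(N)=N/O)cc2)O1` are built from the same atoms joined differently; the difference between the two cores is not broken down here. In an ADME assay on THP-1 cells (Homo sapiens) for cytotoxicity, read by flow cytometry, with a stated time of 72 h (on this read-out higher numbers stand for weaker inhibition and lower numbers for stronger inhibition), compound 1 gives 48400 nM, and compound 2 gives 48100 nM, two values within the scatter of each other. Compound 3 `CC1(Cc2ccccc2)CC(S(=O)(=O)c2ccc(/C=C/c3ccc(/C(N)=N/O)cc3)cc2)=C(c2ccc(/C(N)=N/O)cc2)O1` arises from compound 1 through (a group of 12 heavy atoms (9 carbon, 2 nitrogen, 1 oxygen; one six-membered aromatic ring of carbon only) in place of a group of 11 heavy atoms (7 carbon, 3 nitrogen, 1 oxygen; one six-membered aromatic ring of carbon only), on an aromatic carbon). In this assay compound 3 reaches > 50000 nM, which is a limit of the assay and not a number. The step of an at least 1.0-fold higher number from compound 1 to compound 3 (0.01 log units; that floor lies within the scatter) thus rests on (the limit of > 50000 nM in this assay, at which 1 of the 3 values shown sits). Compound 4 `CC1(Cc2ccccc2)CC(S(=O)(=O)c2ccc(/C(N)=N/O)cc2)=C(c2ccc(/C=C/c3ccc(/C(N)=N/O)cc3)cc2)O1` stands to compound 2 as compound 3 stands to compound 1, through the same change, (a group of 12 heavy atoms (9 carbon, 2 nitrogen, 1 oxygen; one six-membered aromatic ring of carbon only) in place of a group of 11 heavy atoms (7 carbon, 3 nitrogen, 1 oxygen; one six-membered aromatic ring of carbon only), on an aromatic carbon), at a place described in the same words. Since compound 2 gives 48100 nM in this assay and the step of an at least 1.0-fold higher number from compound 1 to compound 3 (0.01 log units; that floor lies within the scatter) was small, the author expects compound 4 to move by a 1.1-fold higher number from compound 2 to compound 4 (0.06 log units; within the scatter). The estimate for compound 4 in this assay is 55000 nM, between 40000 nM and 90000 nM, and it is likely that only a limit is reported.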

Compound 4, half-maximal inhibitory concentration: 23400 nM
For compound 4 the middle estimate is 2.4-fold (0.37 log units) above the measured one; the measured number lies below the stated range.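

On the core of compound 2, the change gives a 2.1-fold lower number from compound 2 to compound 4 (0.31 log units; beyond the scatter) in this assay, a modest step that holds for this one pair of compounds. Compound 3 gives > 50000 nM, which is a limit of the assay and not a number. Set side by side, the two steps therefore neither show that the change carries from one core to the other with the same result nor show that its result depends on the core: the same change on two cores in this assay, an at least 1.0-fold higher number (0.01 log units; that floor lies within the scatter) from compound 1 to compound 3 and a 2.1-fold lower number (0.31 log units; beyond the scatter) from compound 2 to compound 4; the limit leaves it open whether they differ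

The compounds shown leave open how large the step on the core of compound 1 is, and so whether the lower number for compound 4 is particular to its core. They also leave open whether the number in this assay would follow the same course on either core if a carboxylic acid, an amine or a longer chain stood in place of the group that enters here.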